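Halogen Swap on the Ring Amine Nitrogen

This account rests on a few compounds, and the source may have more. Where it says the series, first, only, none or still open, it means among the compounds named here.

In a functional assay on HepG2 cells (Homo sapiens) for antiproliferative activity, read by MTT assay, with a stated time of 48 h (on this read-out lower numbers stand for stronger inhibition and higher numbers for weaker inhibition), three compounds have been measured:
Compound 1 `Cc1ccc(N2CCN(Cn3nc(-c4ccc5c(c4)OCCO5)oc3=S)CC2)c(C)c1` gives 28400 nM.
Compound 2 `S=c1oc(-c2ccc3c(c2)OCCO3)nn1CN1CCN(c2ccc(Cl)cc2)CC1` gives > 50000 nM, which is a limit of the assay.
Compound 3 `S=c1oc(-c2ccc3c(c2)OCCO3)nn1CN1CCN(c2cccc(Cl)c2)CC1` gives > 50000 nM, again a limit and not a number.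

Compound 3 thus sits at the limit of > 50000 nM in this assay, at which 2 of the 3 values shown sit. Compound 4 `Fc1ccc(N2CCN(Cn3nc(-c4ccc5c(c4)OCCO5)oc3=S)CC2)cc1` differs from it by 4-fluorophenyl in place of 3-chlorophenyl on an amine nitrogen in a ring. For the measured compounds named here, the steps that bear on this are an at least 1.7-fold higher number from compound 1 to compound 3 (0.24 log units; that floor lies within the scatter) and an at least 1.7-fold higher number from compound 1 to compound 2 (0.24 log units; that floor lies within the scatter), both only floors, and a step that the two limits leave unreadable from compound 2 to compound 3. Nothing among these points to a gain, so no step beyond the scatter is expected in this assay, and compound 4 is estimated to stay near the limit. The expected step is a number no higher from compound 3 to compound 4 (the limit leaves the size open), giving an estimate for compound 4 of 50000 nM, between 15000 nM and 150000 nM.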

Compound 4, half-maximal inhibitory concentration: > 50000 nM
Compound 4: only a limit was reported; the forecaster's own chance of this, stated with the estimate: 60%; the middle value lies on the limit itself.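

Fluoro in place of chloro on this phenyl ring gives no readable value either, so compounds 2, 3 and 4, all carrying a halogen, now share one limit: the limit of > 50000 nM in this assay, at which 3 of the 4 values shown sit. For the compounds shown here, the one readable step is an at least 1.7-fold higher number from compound 1 to compound 4 (0.24 log units; that floor lies within the scatter). The steps to compound 4 from compound 2 and from compound 3 cannot be read, since both ends are limits.

On these data alone, the true values behind these limits remain open, and so does whether chloro and fluoro differ at all. As far as these compounds go, it is also open whether a methoxy group or a single methyl on this phenyl ring would give a number, as the two methyl groups of compound 1 do.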